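A few compounds are considered here, and "the series" means these few. Any claim that something is new, unique, unknown or untested is made for them only; others in the source may bear on it.

Series notes. For the measured compounds named here, compound 1 `O=C(Nc1ccc(Cl)c(C(=O)Nc2ccc(-c3ncc[nH]3)nc2)c1)c1ccc(Cl)c(Cl)c1` is the only member with a number in hand: in a functional assay on SW480 cells (Homo sapiens) for cytotoxicity, read by MTT assay, with a stated time of 72 h (on this read-out higher numbers stand for weaker inhibition and lower numbers for stronger inhibition), compound 1 gives 9340 nM, and as the sole measured value it stands alone, with no second number to rank it against. Compound 2 `O=C(Nc1ccc(Cl)c(Cl)c1)c1ccc(Cl)c(C(=O)Nc2ccc(-c3ncc[nH]3)nc2)c1` belongs to the same set, but in this assay compound 2 shows "not determined" (no result reported), so it adds nothing to the picture of where compound 1 stands.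

Compound 3 `Cc1cc(C(=O)Nc2ccc(Cl)c(C(=O)Nc3ccc(-c4ncc[nH]4)nc3)c2)ccc1Cl` is the next entry awaiting this assay. It differs from compound 1 in one place: methyl in place of chloro on an aromatic carbon. Going by the values given here, no step between two measured compounds is available, so the size of this change can be judged only from the change itself, and nothing in the measured data points to a direction. The expected step in this assay is a 1.3-fold higher number from compound 1 to compound 3 (0.11 log units; within the scatter), most likely not beyond the scatter. For compound 3 the estimate in this assay is 12000 nM, within a range from 4000 nM to 40000 nM. Should compound 3 fall on the weak side of that range, this assay may report only a limit rather than a number.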

Compound 3, half-maximal inhibitory concentration: 3570 nM
Estimate against measurement, compound 3: 3.4-fold (0.53 log units) above; measured number outside the range, below it.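

In this assay the series gives its first reading of a single change: replacing chloro with methyl, which turns 3,4-dichlorophenyl into 4-chloro-3-methylphenyl, gives a 2.6-fold lower number from compound 1 to compound 3 (0.42 log units; beyond the scatter) and shows that this aromatic carbon, ortho to a chloro group and meta to a large group, responds to substitution and does not need chloro for the lower number. The exchange is one heavy atom for one heavy atom, with no ring, hydrogen-bond donor, hydrogen-bond acceptor or net charge entering or leaving, so even this small edit moves the read-out by a modest step beyond the scatter. Nothing at hand accounts for the direction of this step.

Open, as far as these compounds go, is whether a longer chain such as ethyl, or a methoxy group or an amine on this same carbon, would extend the step or reverse it. Equally open, from the compounds shown here alone, is whether the remaining chloro group of the 4-chloro-3-methylphenyl group can be replaced by methyl or another group with a similar gain, or whether the response is confined to the carbon changed here.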